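This account rests on a few compounds, and the source may have more. Where it says the series, first, only, none or still open, it means among the compounds named here.

In a functional assay on MDA-MB-231 cells (Homo sapiens) for cytotoxicity, read by MTT assay, with a stated time of 24 h (on this read-out higher numbers stand for weaker inhibition and lower numbers for stronger inhibition), compound 3 `NC(=O)c1ccc(-c2nc3cccnc3n2C2CCCC2)cc1` gives 8000 nM, the higher of the two true numbers in the series. Compound 2 `CCNC(=O)c1ccc(-c2nc3cccnc3n2C2CCCC2)cc1` gives the other number, 320 nM. Compound 1 `c1ccc(Oc2ccc(-c3nc4cccnc4n3C3CCCC3)cc2)cc1` gives > 10000 nM, which is a limit of the assay and not a number.

The next change, leading to compound 4 `Cc1nnc(-c2ccc(-c3nc4cccnc4n3C3CCCC3)cc2)o1`, is 5-methyl-1,3,4-oxadiazol-2-yl in place of carbamoyl on an aromatic carbon. For the measured compounds named here, no measured step makes this exact replacement, but three steps act at the same place. Hydrogen in place of ethyl on the amide-type nitrogen gives a 25-fold higher number from compound 2 to compound 3 (1.40 log units; beyond the scatter), a large step. Ethylcarbamoyl in place of phenoxy gives an at least 31-fold lower number from compound 1 to compound 2 (1.49 log units; beyond the scatter), also large, while carbamoyl in place of phenoxy gives an at least 1.2-fold lower number from compound 1 to compound 3 (0.09 log units; that floor lies within the scatter), a floor within the scatter.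

This place is therefore sensitive, but a larger group does not reliably help: compound 2 supports that idea and compound 1 goes against it. A moderate drop is expected, with little confidence in its size, and the estimated step is a 4.0-fold lower number from compound 3 to compound 4 (0.60 log units; beyond the scatter). The estimated value for compound 4 is 2000 nM, with an expected range of 300 nM to 10000 nM.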

Compound 4, half-maximal inhibitory concentration: 21 nM
Beside the measured number, compound 4's estimate is 95-fold (1.98 log units) above it; the whole stated range lies above it.
By their numbers in this assay, from the lowest: compound 4; then compound 2; then compound 3. At a limit, above all of these: compound 1.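

In this assay, an amide is not needed at this position, on an aromatic carbon para to a large group: the 5-methyl-1,3,4-oxadiazol-2-yl group, with its five-membered aromatic ring and 0 hydrogen-bond donors, gives a 380-fold lower number from compound 3 to compound 4 (2.58 log units; beyond the scatter). It also improves on the ethylcarbamoyl group, the best of the earlier groups, with a 15-fold lower number from compound 2 to compound 4 (1.18 log units; beyond the scatter). Compound 1 goes against any reading that removing the amide or placing a ring here is enough, and as its value is a limit and not a number, an at least 470-fold lower number from compound 1 to compound 4 (2.67 log units; beyond the scatter) is only a floor: the limit of > 10000 nM in this assay, at which 1 of the 4 values shown sits.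

As far as these compounds go, whether the methyl on the new ring has any share in the step remains open. So does how a carboxylic acid, an amine or a longer amide chain would compare at this position.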